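Aryl amide change from compound 1 to compound 3

The source may report more compounds than this note shows. Statements on the series, on what has been measured and on what is new or still open speak of the compounds shown alone.

Going by the values given here, in an ADME assay on HaCaT cells (Homo sapiens) for inhibition (on this read-out lower numbers stand for stronger inhibition and higher numbers for weaker inhibition), compound 1 (`COc1cc(-c2cc(C(=O)O)c3ccccc3n2)ccc1OCC(=O)Nc1ccccc1C`) gives 230000 nM as the only number so far. Compound 2 (`COc1cc(-c2cc(C(=O)O)c3ccccc3n2)ccc1OCC(=O)Nc1ccc(C)cc1`) returns only a limit of the assay (> 300000 nM). Compound 3 (`COc1cc(-c2cc(C(=O)O)c3ccccc3n2)ccc1OCC(=O)Nc1cccc(F)c1`) has 3-fluorophenyl in place of 2-methylphenyl on an amide-type nitrogen. Among the compounds with values here, compound 2 is the sole guide at this place, through the measured step (an at least 1.3-fold higher number from compound 1 to compound 2 (0.11 log units; that floor lies within the scatter)), so no change beyond the scatter is expected in this assay. An estimated 1.1-fold higher number from compound 1 to compound 3 (0.04 log units; within the scatter) would stay within the scatter. Compound 3 is expected at 250000 nM with a range of 120000 nM to 300000 nM for now.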

Compound 3, half-maximal inhibitory concentration: 148000 nM
Compound 3: middle estimate off by 1.7-fold (0.23 log units), on the high side; measured number inside the range.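

In this assay, going by these compounds alone, 3-fluorophenyl in place of 2-methylphenyl on the amide-type nitrogen stays within the scatter (a 1.6-fold lower number from compound 1 to compound 3 (0.19 log units; within the scatter)), and this is the first step at this place read between two numbers. The step from 4-methylphenyl gives only a floor (an at least 2.0-fold lower number from compound 2 to compound 3 (0.30 log units; that floor lies within the scatter)), so no order among the three aryl amides can be set. Compound 2 stands at a limit of the assay, not at a number: the limit of > 300000 nM in this assay, at which 1 of the 3 values shown sits.

Open, going by these compounds, is whether an amine or a carboxylic acid in place of the fluorine of 3-fluorophenyl would move the number beyond the scatter in this assay.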